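The source may report more compounds than this note shows. Statements on the series, on what has been measured and on what is new or still open speak of the compounds shown alone.

Compound 1, `O=C1C(c2ccccc2)CC(c2ccccc2)C(=O)N1Cc1ccccc1`, in a functional assay on the whole organism (strain Swiss albino) with Mus musculus as the target, in the maximal electroshock model, with a stated time of 2 h (a lower number here means that less compound is needed, a higher number that more compound is needed for the effect), gives 14 mg/kg.
Compound 2, `NN1C(=O)C(c2ccccc2)CC(c2ccccc2)C1=O`, in this assay gives 10 mg/kg.
Compound 3, `O=C1C(c2ccccc2Cl)CC(c2ccccc2Cl)C(=O)N1Cc1ccccc1`, in this assay gives 38.3 mg/kg.

Compound 1 and compound 2 share a core and differ in one place: amino in place of benzyl on an amide-type nitrogen in a ring. That change gave a 1.4-fold lower number from compound 1 to compound 2 (0.15 log units; within the scatter), so the two numbers lie within the usual scatter and no order between them can be read. Compound 3 carries a different core; how its core differs from the core of compound 1 is not broken down here. Its number is the highest of the three, and its distance to compound 1 and to compound 2 lies beyond the scatter.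

Compound 4, `NN1C(=O)C(c2ccccc2Cl)CC(c2ccccc2Cl)C1=O`, has not yet been measured. It relates to compound 3 as compound 2 relates to compound 1: amino in place of benzyl on an amide-type nitrogen in a ring. This is the same kind of change, though the surroundings differ: in compound 1 the two ring atoms each bear a phenyl group, in compound 3 a 2-chlorophenyl group. Among the compounds with values here, with only one earlier example of this change, the step is expected to be of similar size, and compound 4 is expected to give 27 mg/kg in this assay, between 14 mg/kg and 55 mg/kg. This means an expected step of a 1.4-fold lower number from compound 3 to compound 4 (0.15 log units; within the scatter). The expectation rests on compound 1 and compound 2, where the same change gave a 1.4-fold lower number from compound 1 to compound 2 (0.15 log units; within the scatter), and on compound 3 with its 38.3 mg/kg as the starting point.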

Compound 4, dose for half-maximal effect: 11.2 mg/kg
Beside the measured number, compound 4's estimate is 2.4-fold (0.38 log units) above it; measured number below the stated range.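

In this assay, taking the benzyl group off the ring nitrogen and putting an amino group there, on the core whose two ring atoms each bear a 2-chlorophenyl group, gave a 3.4-fold lower number from compound 3 to compound 4 (0.53 log units; beyond the scatter), and this step, unlike the earlier one on the core of compound 1, is large enough to be read on its own. Set side by side, the two steps cannot be told apart in size, so as far as these two pairs go, the change carries from one core to the other without a visible difference: the same change on two cores in this assay, a 1.4-fold lower number (0.15 log units; within the scatter) from compound 1 to compound 2 and a 3.4-fold lower number (0.53 log units; beyond the scatter) from compound 3 to compound 4, 2.4-fold (0.39 log units) apart, within the scatter of two such steps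

This does not show that the 2-chlorophenyl groups make the change larger, even though only the second step lies beyond the scatter, and two pairs are too few to set a rule for other cores.

The compounds shown leave open how the numbers would move with a different group on this nitrogen, such as a methyl group, a longer chain or a carboxylic acid. They also leave open whether the step between benzyl and amino would look the same on a core bearing other groups on those two ring atoms, such as fluorophenyl or methoxyphenyl.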